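Swapping a benzyl for a phenoxy group on the shared core

A few compounds are considered here, and "the series" means these few. Any claim that something is new, unique, unknown or untested is made for them only; others in the source may bear on it.

Measured compounds:
- compound 1, `COc1ccc(F)cc1CNCCCNc1ccnc2cc(Cc3cc(C)cc(C)c3)ccc12`: 9.47
- compound 2, `COc1cccc(CNCCCNc2ccnc3cc(Oc4ccc(Cl)cc4)ccc23)c1O`: 9.28

The read-out is a physicochemical assay for acid dissociation. Among the two numbers, compound 1 gives the higher value, with compound 2 sitting a little lower, but the gap between them lies within the usual scatter, so no real order can be read from it.

Compound 3, `COc1cccc(Oc2ccc3c(NCCCNCc4cc(F)ccc4OC)ccnc3c2)c1`, has not been measured. It differs from compound 1 in one place: 3-methoxyphenoxy in place of 3,5-dimethylbenzyl on an aromatic carbon. The exchanged group sits on the shared core, away from the nitrogen atoms that take up a proton, and compound 2, which also carries a phenoxy-type group on its core, gives a value close to that of compound 1.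

For this reason the step of a number 0.12 log units lower from compound 1 to compound 3 (within the scatter) is expected to be small, with no direction beyond the scatter. Compound 3 is estimated at 9.35, within a range of 9.05 to 9.65.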

Compound 3, acid dissociation constant: 9.28
For compound 3 the middle estimate is 0.07 log units above the measured one; measured number inside the range.
By their numbers in this assay, from the lowest: compounds 2, 3 and 1 (each within the scatter of the next).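

In this assay, 3-methoxyphenoxy in place of 3,5-dimethylbenzyl on an aromatic carbon of the shared core gives a number 0.19 log units lower from compound 1 to compound 3 (within the scatter). Going by these compounds alone, this pair differs in one place only, so it offers the first direct reading at this position: a group with 2 hydrogen-bond acceptors and one with 0 cannot be told apart here. Nothing at hand bears on the reason for this result.

Going by these compounds, both groups compared carry a six-membered aromatic ring of carbon only, and it remains open whether the number would stay put with a carboxylic acid or an amine on this carbon. Also open, on these data alone, is how the number would respond to a longer chain between the nitrogen atoms of the side chain.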